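Swapping the ether side chain on a brominated diaryl ether

A few compounds are considered here, and "the series" means these few. Any claim that something is new, unique, unknown or untested is made for them only; others in the source may bear on it.

Measured so far, in a functional assay on U-937 cells (Homo sapiens) for cytotoxicity, read by MTT assay, with a stated time of 24 h; a lower number here means a stronger inhibitor, a higher number a weaker inhibitor:
compound 1 `C=CCOc1c(Br)cc(Br)cc1Oc1ccc(Br)cc1Br` gives 29 ug/mL;
compound 2 `CCOC(=O)C(C)Oc1c(Br)cc(Br)cc1Oc1ccc(Br)cc1Br` gives 39.5 ug/mL.

Compound 2 has the highest of the two numbers, but the step of a 1.4-fold higher number from compound 1 to compound 2 (0.13 log units; within the scatter) is within the scatter, so compound 1 and compound 2 cannot be told apart. Compound 3 `CC(C)(C)C(=O)C(C#N)Oc1c(Br)cc(Br)cc1Oc1ccc(Br)cc1Br` is not yet measured. It keeps the shared core of compound 2 and changes only the group on the ether oxygen: cyano((tert-butyl)carbonyl)methyl in place of 1-(ethoxycarbonyl)ethyl on an oxygen on an aromatic ring. For the measured compounds named here, the one measured step, from compound 1 to compound 2, also changed this same group and stayed within the scatter, so this position tolerated one exchange without a visible effect. The step from compound 2 to compound 3 is therefore expected to be small too, a 1.1-fold lower number from compound 2 to compound 3 (0.05 log units; within the scatter), in no particular direction. For compound 3 the estimate in this assay is 35 ug/mL, with a range from 15 ug/mL to 80 ug/mL.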

Compound 3, half-maximal inhibitory concentration: 32.5 ug/mL
Compound 3: middle estimate off by 1.1-fold (0.03 log units), on the high side; measured number inside the range.
By their numbers in this assay, from the lowest: compounds 1, 3 and 2 (each within the scatter of the next).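

In this assay, placing cyano((tert-butyl)carbonyl)methyl on the oxygen instead of 1-(ethoxycarbonyl)ethyl gives a 1.2-fold lower number from compound 2 to compound 3 (0.08 log units; within the scatter) and, instead of allyl, gives a 1.1-fold higher number from compound 1 to compound 3 (0.05 log units; within the scatter) in this comparison. For the compounds shown here, the earlier pair showed only one exchange at this position, whereas three different groups can now be compared, and none can be told apart from the others, even though the new group is the only one of the three with a nitrile and a tert-butyl group. No measurement available here explains why the number stays within the scatter.

On these data alone, all three groups are uncharged chains without a ring, so it remains open whether an amine, a carboxylic acid or a phenyl ring on this oxygen would shift the number beyond the scatter. As far as these compounds go, a free hydroxyl group in place of the ether is equally open, as is any change to the bromines on the shared core.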